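Salicylanilide series: bromo in place of methoxy on the anilide

A few compounds are considered here, and "the series" means these few. Any claim that something is new, unique, unknown or untested is made for them only; others in the source may bear on it.

Compound 1 `NC(=O)c1ccc(O)c(C(=O)Nc2cc(C(F)(F)F)cc(C(F)(F)F)c2)c1` in an assay for inhibition of transmembrane protease serine 4 (Homo sapiens), read by fluorescence (on this read-out higher numbers stand for weaker inhibition and lower numbers for stronger inhibition), gives only an assay limit, > 100000 nM.
Compound 2 `COc1cc(NC(=O)c2cc(Cl)ccc2O)cc(C(F)(F)F)c1` in this assay gives 16000 nM.

Within the data shown here, compound 2 holds the only numeric value shown so far. Compound 1 sits at the limit of > 100000 nM in this assay, at which 1 of the 2 values shown sits. Compound 3 `O=C(Nc1cc(Br)cc(C(F)(F)F)c1)c1cc(Cl)ccc1O` differs from compound 2 by bromo in place of methoxy on an aromatic carbon, meta to a trifluoromethyl group. Among the measured compounds shown here, no measured step of this kind exists in the set, so only a modest shift in this assay is expected, likely within the usual scatter. Compound 3 is expected near 12000 nM (range 3000 nM to 50000 nM), an expected step of a 1.3-fold lower number from compound 2 to compound 3 (0.12 log units; within the scatter).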

Compound 3, half-maximal inhibitory concentration: 12000 nM
Beside the measured number, compound 3's estimate shows no gap at the digits printed; measured number inside the range.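

At this position, meta to a trifluoromethyl group, bromo in place of methoxy gives a 1.3-fold lower number from compound 2 to compound 3 (0.12 log units; within the scatter) in this assay, the first step read here. The change removes the hydrogen-bond acceptor of the methoxy, yet the two compounds stay within the scatter of each other. Among these compounds, nothing measured so far accounts for this step.

From the compounds shown here alone, whether an amine or a carboxylic acid at this position would give a step beyond the scatter remains open. So does the contribution of the chloro group elsewhere on the shared core.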